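A reversed amide with a basic tail on a weak series

The source may report more compounds than this note shows. Statements on the series, on what has been measured and on what is new or still open speak of the compounds shown alone.

Compound 1 `O=C(c1cccc(Nc2ncc(F)c(Nc3ccc(F)cc3)n2)c1)N1CCCCC1` anchors this small set. In a functional assay on DU-145 cells (Homo sapiens) for antiproliferative activity, read by sulforhodamine B assay, with a stated time of 3 days (on this read-out higher numbers stand for weaker inhibition of growth and lower numbers for stronger inhibition of growth), compound 1 gives 13000 nM, the lower of the two numbers measured, although the gap to compound 3 `O=C(Nc1cc(Cl)cc(Cl)c1)c1cccc(Nc2ncc(F)c(Nc3ccc(F)cc3)n2)c1` is within the scatter: compound 3 gives 17500 nM, and the step of a 1.3-fold higher number from compound 1 to compound 3 (0.13 log units; within the scatter) changes nothing beyond the scatter. Compound 2 `O=C(Nc1cccc(Nc2ncc(F)c(Nc3ccc(F)cc3)n2)c1)c1ccccc1` is reported only as a limit, > 10000 nM. The step that the limit leaves unreadable from compound 1 to compound 2 therefore cannot be sized because of the limit of > 10000 nM in this assay, at which 1 of the 3 values shown sits.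

Compound 4 `CN(C)CC(=O)Nc1cccc(Nc2ncc(F)c(Nc3ccc(F)cc3)n2)c1` differs from compound 1 in one place: (((dimethylamino)methyl)carbonyl)amino in place of (piperidin-1-yl)carbonyl on an aromatic carbon. Of the measured steps, a 1.3-fold higher number from compound 1 to compound 3 (0.13 log units; within the scatter) is the only readable one, and it alters the group on the carbonyl carbon without moving the number beyond the scatter. The step that the limit leaves unreadable from compound 1 to compound 2 also replaces a carbonyl attachment with an amido attachment on the aromatic carbon, as the change to compound 4 does, but it stays behind the limit and leaves open whether such a change weakens growth inhibition. The data thus give no sign of a step beyond the scatter in either direction, while the limit on compound 2 leaves room for a weaker number. The step of a 1.2-fold higher number from compound 1 to compound 4 (0.06 log units; within the scatter) is expected to remain within the scatter. Compound 4 is estimated at 15000 nM, with a range from 5000 nM to 40000 nM.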

Compound 4, concentration for 50% growth inhibition: 1210 nM
Compound 4: the middle estimate sits 12-fold (1.09 log units) above what was measured; the whole stated range lies above it.
By their numbers in this assay, from the lowest: compound 4; then compounds 1 and 3 (each within the scatter of the next).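

In this assay, this position gives its first readable movement beyond the scatter, a large one: an 11-fold lower number from compound 1 to compound 4 (1.03 log units; beyond the scatter), and likewise a 14-fold lower number from compound 3 to compound 4 (1.16 log units; beyond the scatter), whereas the earlier swap of piperidin-1-yl for (3,5-dichlorophenyl)amino on the carbonyl carbon stayed within the scatter. With the amido attachment held in place, (dimethylamino)methyl in place of phenyl on the carbonyl carbon also goes with a lower number, an at least 8.2-fold lower number from compound 2 to compound 4 (0.91 log units; beyond the scatter), so among these compounds the lower number follows the (((dimethylamino)methyl)carbonyl)amino group and not the amido attachment alone. Compound 2 stands only as a limit, so its step is a bound and not a size, while its other steps cannot be read: the limit of > 10000 nM in this assay, at which 1 of the 4 values shown sits.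

On these data alone, it remains open whether the dimethylamino group itself carries the step, which a plain acetamido group with no amine would test. As far as these compounds go, it is equally open whether a cyclic amine such as pyrrolidine or morpholine, or a longer chain between the carbonyl and the amine, would keep the number this low.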